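The source may hold more compounds than are shown below. What is called first, only, known or untested is meant among the compounds shown, and "the series" means these compounds.

Of the compounds shown here, two have been measured in an assay on RAW264.7 cells for antagonist activity at Toll-like receptor 2 (Mus musculus), read by Griess assay, with a stated time of 24 h; a higher number here means a weaker inhibitor, a lower number a stronger inhibitor. Compound 1 `COC(=O)[C@H](CSCc1ccc(F)cc1)NC(=O)c1cc(O)c(O)c(O)c1` gives 50200 nM. Compound 2 `C=CCCCSC[C@H](NC(=O)c1cc(O)cc(O)c1)C(=O)OC` gives 57800 nM, the higher of the two numbers, but the gap to compound 1 lies within the scatter of repeated measurements, so the two cannot be told apart on these figures.

Compound 3 `COC(=O)[C@H](CSCc1ccc(F)cc1)NC(=O)c1cc(O)cc(O)c1` is not yet measured. It differs from compound 2 in one place: 4-fluorophenyl in place of but-3-en-1-yl on a saturated chain carbon bound to a sulfur. Compound 3 thereby carries the same group on the saturated chain carbon bound to a sulfur as compound 1, while keeping the core of compound 2. Going by the values given here, no measured pair shows this change on its own, so no step size is known for it. Because compound 1 gives 50200 nM and compound 2 gives 57800 nM, close to each other, compound 3 is expected to land near both, with an estimated step from compound 2 of a 1.2-fold lower number from compound 2 to compound 3 (0.06 log units; within the scatter), nothing beyond the scatter. The expected value for compound 3 in this assay is 50000 nM, with a likely range from 25000 nM to 100000 nM.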

Compound 3, half-maximal inhibitory concentration: 38400 nM
Compound 3: the middle estimate sits 1.3-fold (0.11 log units) above what was measured, within the range that was stated.
By their numbers in this assay, from the lowest: compounds 3, 1 and 2 (each within the scatter of the next).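

In this assay, going by these compounds alone, the step for 4-fluorophenyl in place of but-3-en-1-yl on a saturated chain carbon bound to a sulfur is a 1.5-fold lower number from compound 2 to compound 3 (0.18 log units; within the scatter) and gives the first direct reading of this change: an aromatic ring and an open chain with a double bond cannot be told apart at this place. The step for hydrogen in place of hydroxy on an aromatic carbon is a 1.3-fold lower number from compound 1 to compound 3 (0.12 log units; within the scatter) and likewise shows no difference that can be told from the scatter. No measurement at hand explains these readings.

On these data alone, it remains open whether an amine on the chain at this place, or a carboxylic acid in place of the methyl ester, would move the number beyond the scatter. A much longer chain at this place is equally untested here.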